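The source may report more compounds than this note shows. Statements on the series, on what has been measured and on what is new or still open speak of the compounds shown alone.

Measured compounds in an ADME assay on microsomes from liver (Rattus norvegicus) for metabolic stability, with a stated time of 10 min; on this read-out lower numbers stand for a less stable compound and higher numbers for a more stable compound:
- compound 1 `O=C(NS(=O)(=O)c1ccccc1)c1ccc(Nc2nc(NC3(c4ccc(Cl)cc4)CC3)nc(OCC(F)(F)F)n2)cc1`: 100%
- compound 2 `CC(C)NC(=O)NCCS(=O)(=O)NC(=O)c1ccc(Nc2nc(NC3(c4ccc(Cl)cc4)CC3)nc(OCC(F)(F)F)n2)cc1`: 97%

On the numbers shown compound 2 sits alongside compound 1; the step of a number 3 percentage points lower from compound 1 to compound 2 (within the scatter) lies within the scatter, so the two compounds are not told apart on this read-out, and both sit at the upper end of it.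

Compound 3 `CC(=O)NCCS(=O)(=O)NC(=O)c1ccc(Nc2nc(NC3(c4ccc(Cl)cc4)CC3)nc(OCC(F)(F)F)n2)cc1` differs from compound 2 by methyl in place of isopropylamino on a carbonyl carbon. For the measured compounds named here, no measured step touches this carbonyl carbon. Going by the values given here, the only measured step, a number 3 percentage points lower from compound 1 to compound 2 (within the scatter), exchanged the group on the sulfonyl sulfur and stayed within the scatter, and the common part of compounds 1 and 2 already carries the read-out near its top. On that basis compound 3 is expected to stay close to compound 2, with a step of a number 2 percentage points lower from compound 2 to compound 3 (within the scatter), none beyond the scatter. Compound 3 is therefore estimated at 95%, with a range from 85% to 100%.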

Compound 3, percent of the compound remaining: 100%
Compound 3: the middle estimate sits 5 percentage points below what was measured; measured number inside the range.
By their numbers in this assay, from the lowest: compounds 2, 1 and 3 (each within the scatter of the next).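

The carbonyl carbon is now covered by a measured step: in this assay, methyl in place of isopropylamino gives a number 3 percentage points higher from compound 2 to compound 3 (within the scatter), so compound 2 and compound 3 are not told apart, even though the change removes the isopropylamino group and its hydrogen-bond donor. The group on the sulfonyl sulfur also gains a second exchange, with 2-acetamidoethyl in place of phenyl giving no change at the digits printed from compound 1 to compound 3 (within the scatter), which again leaves the two compounds unresolved. No supporting evidence is available to explain these results.

With all three compounds at the upper end of the read-out, no change shown has yet separated one compound from another. Going by these compounds, a free amine or a carboxylic acid in place of the acetamido group, or a longer chain on the sulfonyl sulfur, remains open.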